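The source may report more compounds than this note shows. Statements on the series, on what has been measured and on what is new or still open speak of the compounds shown alone.

In a functional assay on HeLa cells (Homo sapiens) for inhibition, read by MTT assay, with a stated time of 48 h (on this read-out lower numbers stand for stronger inhibition and higher numbers for weaker inhibition), two compounds sharing one core have been measured so far. Compound 1 `CCOC(=O)C1=C(NN=C(C#N)C#N)Nc2[nH]nc(C)c2C1c1ccc(N(C)C)cc1` gives 15200 nM. Compound 2 `CCOC(=O)C1=C(N/C=N/c2ccccn2)Nc2[nH]nc(C)c2C1c1ccc(N(C)C)cc1` gives 29200 nM. These two numbers lie within the usual scatter of each other, so compound 2 cannot be told apart from compound 1 on these data.

Compound 3 `CCOC(=O)C1=C(N)Nc2[nH]nc(C)c2C1c1ccc(N(C)C)cc1` differs from compound 2 at a single place: a hydrogen atom in place of a group of 8 heavy atoms (6 carbon, 2 nitrogen; one six-membered aromatic ring with 1 hetero atom), on an amine nitrogen. This leaves a plain hydrogen on an amine nitrogen whose other neighbour is a double-bonded ring carbon.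

Among the measured compounds shown here, only one measured step bears on this change: a 1.9-fold higher number from compound 1 to compound 2 (0.28 log units; within the scatter). There, one group on that amine nitrogen was exchanged for another, and the number stayed within the scatter. Neither measured compound has a hydrogen at this place, so the data cannot show what losing the group does. The working expectation is therefore no step beyond the scatter, with no direction favoured, though with real uncertainty.

The estimate implies an expected 1.2-fold lower number from compound 2 to compound 3 (0.07 log units; within the scatter). For compound 3, the estimated value is 25000 nM, with an expected range from 9000 nM to 70000 nM.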

Compound 3, half-maximal inhibitory concentration: 6220 nM
Estimate against measurement, compound 3: 4.0-fold (0.60 log units) above; measured number outside the range, below it.
By their numbers in this assay, from the lowest: compound 3; then compounds 1 and 2 (each within the scatter of the next).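

In this assay, this amine nitrogen now shows a step beyond the scatter: replacing the group of compound 2 with a plain hydrogen gives a 4.7-fold lower number from compound 2 to compound 3 (0.67 log units; beyond the scatter), and replacing the group of compound 1 gives a 2.4-fold lower number from compound 1 to compound 3 (0.39 log units; beyond the scatter). Exchanging one group for the other had stayed within the scatter, at a 1.9-fold higher number from compound 1 to compound 2 (0.28 log units; within the scatter), so only the bare hydrogen separates itself, and compound 3 has the strongest inhibition of the three, though both steps are modest. Neither large group on this nitrogen is therefore needed for the inhibition seen here, but no measurement given here explains the change.

The compounds shown jump from a hydrogen straight to groups of several heavy atoms, leaving open whether the number rises gradually with group size or depends on the kind of group. A methyl or an acetyl on this nitrogen would help separate those possibilities, showing whether a small group keeps the lower number of compound 3 or whether the plain hydrogen itself matters.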